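Quinolin-2-yl in place of 4-fluorophenyl on the amide

A few compounds are considered here, and "the series" means these few. Any claim that something is new, unique, unknown or untested is made for them only; others in the source may bear on it.

Measured compounds:
Compound 1, `CN1[C@@H]2c3[nH]c4ccccc4c3C[C@H]1[C@H](C#N)N1[C@@H](CN3C(=O)c4ccccc4C3=O)c3[nH]c4ccccc4c3C[C@@H]21`: 40 nM
Compound 2, `CN1[C@@H]2c3[nH]c4ccccc4c3C[C@H]1[C@H](C#N)N1[C@@H](CNC(=O)c3ccc(F)cc3)c3[nH]c4ccccc4c3C[C@@H]21`: 140 nM

Among the measured compounds shown here, in a functional assay on HCT-116 cells (Homo sapiens) for cytotoxicity, read by MTT assay, with a stated time of 72 h (a higher number here means a weaker inhibitor, a lower number a stronger inhibitor), compound 2 gives 140 nM, the higher of the two numbers measured so far. For the measured compounds named here, its nearest neighbour is compound 1, which in this assay gives 40 nM; the only step measured, a 3.5-fold higher number from compound 1 to compound 2 (0.54 log units; beyond the scatter), lies beyond the scatter and is modest in size.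

Compound 3, `CN1[C@@H]2c3[nH]c4ccccc4c3C[C@H]1[C@H](C#N)N1[C@@H](CNC(=O)c3ccc4ccccc4n3)c3[nH]c4ccccc4c3C[C@@H]21`, is not yet measured in this assay. It differs from compound 2 by quinolin-2-yl in place of 4-fluorophenyl on a carbonyl carbon. Going by the values given here, the one measured step concerns a different place on the shared core, the exchange of the group on the saturated chain carbon, and so does not bear directly on the exchange of the aryl group on the carbonyl carbon. Among the compounds with values here, no measured pair shows what replacing 4-fluorophenyl by quinolin-2-yl does here.

Within the data shown here, with no step to lean on, compound 3 is expected to give a number close to that of compound 2, a step of a 1.1-fold lower number from compound 2 to compound 3 (0.03 log units; within the scatter), within the scatter. The estimate for compound 3 in this assay is 130 nM, with a range from 40 nM to 450 nM.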

Compound 3, half-maximal inhibitory concentration: 240 nM
For compound 3 the middle estimate is 1.8-fold (0.27 log units) below the measured one, within the range that was stated.
By their numbers in this assay, from the lowest: compound 1; then compounds 2 and 3 (each within the scatter of the next).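

In this assay the exchange on the carbonyl carbon bound to the amide-type nitrogen gives a 1.7-fold higher number from compound 2 to compound 3 (0.23 log units; within the scatter) and so leaves compound 3 and compound 2 indistinguishable. Among the compounds shown here, this is the first reading at this place, and it shows that the single ring of 4-fluorophenyl can give way to the two rings of quinolin-2-yl, with 10 heavy atoms instead of 7 and a hydrogen-bond acceptor instead of none, without a step that can be read beyond the scatter. No measurement is available that would account for this result.

The compounds shown leave open whether a group of another kind on the same carbonyl carbon, such as a longer alkyl chain, an aminophenyl or a carboxyphenyl group, would move the number beyond the scatter. They also leave open whether pyridin-2-yl, a single ring that carries the ring nitrogen without the second ring, would read like quinolin-2-yl or like 4-fluorophenyl in this assay, and so which part of the quinolin-2-yl group, if any, matters here.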